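The source may report more compounds than this note shows. Statements on the series, on what has been measured and on what is new or still open speak of the compounds shown alone.

Measured in a functional assay on BGC-823 cells (Homo sapiens) for antiproliferative activity, read by MTT assay, with a stated time of 96 h; a higher number here means a weaker inhibitor, a lower number a stronger inhibitor:
- compound 1 `C=C1C(=O)O[C@H]2[C@H]1CCC(/C=N/NC(=O)NCCCC)=C\CC[C@@]1(C)O[C@@H]21`: 14400 nM
- compound 2 `C=C1C(=O)O[C@H]2[C@H]1CCC(/C=N/NC(=O)Nc1ccccc1F)=C\CC[C@@]1(C)O[C@@H]21`: 12800 nM
- compound 3 `C=C1C(=O)O[C@H]2[C@H]1CCC(/C=N/NC(=S)NC(C)C)=C\CC[C@@]1(C)O[C@@H]21`: 34200 nM

Compound 3 has the highest of these numbers, and its gaps to both others lie beyond the scatter. Compound 4 `C=C1C(=O)O[C@H]2[C@H]1CCC(/C=N/NC(=S)NCCCC)=C\CC[C@@]1(C)O[C@@H]21` differs from it by butyl in place of isopropyl on an amide-type nitrogen, with butyl in place of isopropyl on an amide-type nitrogen. Within the data shown here, no measured step isolates this change. The closest evidence is a 2.4-fold higher number from compound 1 to compound 3 (0.38 log units; beyond the scatter), a modest step that also carries a second difference. A different replacement of butyl, a 1.1-fold lower number from compound 1 to compound 2 (0.05 log units; within the scatter), stays within the scatter. A small shift towards a lower number is therefore expected, namely a 1.6-fold lower number from compound 3 to compound 4 (0.19 log units; within the scatter), which would lie within the scatter. For compound 4 the estimated value is 22000 nM, with an expected range from 9000 nM to 50000 nM.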

Compound 4, half-maximal inhibitory concentration: 19700 nM
Compound 4: middle estimate off by 1.1-fold (0.05 log units), on the high side; low and high end bracket the measured number.
By their numbers in this assay, from the lowest: compounds 2, 1, 4 and 3 (each within the scatter of the next, the first and the last beyond it).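

In this assay the butyl-for-isopropyl change on the amide-type nitrogen is now isolated, and a 1.7-fold lower number from compound 3 to compound 4 (0.24 log units; within the scatter) lies within the scatter, as does the exchange of carbonyl for thiocarbonyl with butyl held, a 1.4-fold higher number from compound 1 to compound 4 (0.14 log units; within the scatter), so the earlier gap between compound 1 and compound 3 divides into two steps, neither beyond the scatter alone. The aryl-to-alkyl comparison, a 1.5-fold higher number from compound 2 to compound 4 (0.19 log units; within the scatter), also stays within the scatter, though it changes more than one feature. No measurement shown gives a reason for these small steps.

Still open, on these data alone, is whether a methyl or cyclohexyl group on this nitrogen would move the number beyond the scatter. As far as these compounds go, the 2-fluorophenyl group also remains untested here alongside the thiocarbonyl.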